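Trimming the methoxyethyl chain on the weakest compound

A few compounds are considered here, and "the series" means these few. Any claim that something is new, unique, unknown or untested is made for them only; others in the source may bear on it.

A set of three compounds sharing one core has been run in a functional assay on HEK293 cells for agonist activity at G-protein coupled receptor 39 (Mus musculus), read by inositol phosphate accumulation; on this read-out higher numbers stand for an effect only at larger amounts of compound and lower numbers for an effect already at smaller amounts. Compound 1 `COCCNc1nc(NCC2CC2)cc(-c2ccccn2)n1` gives 10000 nM in this assay and stands at the highest number of the three. Compound 2 `Cc1nc(NCc2ccc(Cl)cc2)cc(-c2ccccn2)n1` gives 17 nM, and compound 3 `CNc1nc(NC2(c3ccc(Cl)cc3)CCC2)cc(-c2ccccn2)n1` gives 34 nM; both gaps to compound 1 are far beyond the scatter. Compound 3 carries a methylamino group on the core, the group that the change described below would create, but it also carries a different second amine, so the two compounds differ in more than one place and no single step can be read from them.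

Compound 4 `CNc1nc(NCC2CC2)cc(-c2ccccn2)n1` has not yet been measured. It differs from compound 1 in one place: hydrogen in place of methoxymethyl on a saturated chain carbon bound to a nitrogen on an aromatic ring. Among the compounds with values here, since no measured pair isolates this change, the expectation rests only on the spread seen among the three compounds. The step from compound 1 to compound 4 is expected to move toward a lower number, by a modest amount, a 3.3-fold lower number from compound 1 to compound 4 (0.52 log units; beyond the scatter). Compound 4 is therefore estimated at 3000 nM, with a range from 500 nM to 10000 nM.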

Compound 4, half-maximal effective concentration: 115 nM
Estimate against measurement, compound 4: 26-fold (1.42 log units) above; the whole stated range lies above it.
By their numbers in this assay, from the lowest: compounds 2 and 3 (each within the scatter of the next); then compound 4; then compound 1.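

Within this assay the exchange of (2-methoxyethyl)amino for methylamino gives an 87-fold lower number from compound 1 to compound 4 (1.94 log units; beyond the scatter) with the rest of the structure unchanged. Within the data shown here, this is the first single-place comparison in the set, and it shows that the read-out is highly sensitive to the group at this position: removing the methoxymethyl end of the chain alone produces a large step. Nothing available here explains why the step is so large.

The compounds shown leave open how an ethyl chain, a 2-hydroxyethyl chain or a plain amino group at this place would compare with methylamino and 2-methoxyethylamino. They also leave open whether a step of this size would appear if the same exchange were made alongside the second amine of compound 3.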